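The source may report more compounds than this note shows. Statements on the series, on what has been measured and on what is new or still open speak of the compounds shown alone.

In a functional assay on GTL 16 cells for antiproliferative activity against GTL 16 cell line (Homo sapiens), read by CCK-8 assay, with a stated time of 72 h (a higher number here means a weaker inhibitor, a lower number a stronger inhibitor), compound 1 `Cc1ccc(C(=O)Nc2cccc(-c3oc4cc(-c5ccc(F)cc5)ccc4c(=O)c3O)c2)cc1` gives 12900 nM, the second highest of the three numbers recorded so far. Its nearest neighbour is compound 3 `Cc1cc(C)cc(C(=O)Nc2cccc(-c3oc4cc(-c5ccc(F)cc5)ccc4c(=O)c3O)c2)c1`, which gives 13500 nM in this assay; the furthest is compound 2 `O=C(Nc1cccc(-c2oc3cc(-c4ccc(F)cc4)ccc3c(=O)c2O)c1)c1ccc(F)cc1F`, which gives 9640 nM in this assay. The three measured steps are all small: a 1.3-fold lower number from compound 1 to compound 2 (0.13 log units; within the scatter), a 1.0-fold higher number from compound 1 to compound 3 (0.02 log units; within the scatter) and a 1.4-fold higher number from compound 2 to compound 3 (0.15 log units; within the scatter). Each of these steps alters the aryl group on the carbonyl carbon of the amide, and none of them moves the number beyond the scatter.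

Compound 4 `N#Cc1ccc(C(=O)Nc2cccc(-c3oc4cc(-c5ccc(F)cc5)ccc4c(=O)c3O)c2)cc1` is the unmeasured member of the set. It differs from compound 1 in one place: cyano in place of methyl on an aromatic carbon. Among the compounds with values here, no measured step introduces a cyano group, so the earlier steps bear on this change only indirectly. What they do show is that three different aryl groups on the carbonyl carbon gave numbers within the scatter of one another, with no group standing apart. On that basis the expected step is a 1.1-fold lower number from compound 1 to compound 4 (0.05 log units; within the scatter), that is, nothing beyond the scatter in either direction. Compound 4 is therefore estimated to give 11500 nM in this assay, with a range from 5000 nM to 26000 nM.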

Compound 4, half-maximal inhibitory concentration: 31800 nM
Compound 4: the middle estimate sits 2.8-fold (0.44 log units) below what was measured, and the stated range ends below it.
By their numbers in this assay, from the lowest: compounds 2, 1 and 3 (each within the scatter of the next); then compound 4.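

In this assay, within the data shown here, the aryl group on the carbonyl carbon of the amide now proves able to move the number: cyano in place of methyl, on an aromatic carbon para to a large group, gives the only kind of step in this set that lies beyond the scatter, though a modest one (a 2.5-fold higher number from compound 1 to compound 4 (0.39 log units; beyond the scatter)). The 4-cyanophenyl group stands apart from the other two aryl groups as well (a 2.4-fold higher number from compound 3 to compound 4 (0.37 log units; beyond the scatter); a 3.3-fold higher number from compound 2 to compound 4 (0.52 log units; beyond the scatter)), and all three steps run the same way, so the tolerance seen among compounds 1, 2 and 3 does not extend to compound 4. Nothing measured here accounts for this shift.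

The compounds shown leave open whether the higher number is particular to the nitrile or would also appear with a carboxamide, a carboxylic acid or an amine in the same place. They also leave open whether a cyano group elsewhere on this ring would give a step of similar size.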